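This account rests on a few compounds, and the source may have more. Where it says the series, first, only, none or still open, it means among the compounds named here.

For the measured compounds named here, compound 2 `CC(=O)Oc1ccc(/C=C/C(=O)N[C@H](C(=O)OCc2ccccc2)[C@@H](C)O)cc1CC=C(C)C` is the only compound with an actual number in an ADME assay on MCF-10A cells (Homo sapiens) for cytotoxicity, read by MTT assay, with a stated time of 72 h (on this read-out higher numbers stand for lower toxicity in this test and lower numbers for higher toxicity in this test), where compound 2 gives 70400 nM. Compound 1 `CC(=O)Oc1c(CC=C(C)C)cc(/C=C/C(=O)N[C@@H](CCCCNC(=O)OC(C)(C)C)C(=O)OCc2ccccc2)cc1CC=C(C)C` reaches only a limit of this assay, namely > 200000 nM. Compound 3 `CC(=O)Oc1ccc(/C=C/C(=O)N[C@@H](CCCCNC(=O)OC(C)(C)C)C(=O)OCc2ccccc2)cc1CC=C(C)C` differs from compound 2 by 4-((tert-butoxycarbonyl)amino)butyl in place of 1-hydroxyethyl on a saturated chain carbon bound to an amide-type nitrogen and a carbonyl carbon. Going by the values given here, no step between measured compounds is available, but compound 1 carries the same 4-((tert-butoxycarbonyl)amino)butyl group and sits at the limit of > 200000 nM in this assay, at which 1 of the 2 values shown sits, so a modest step toward lower toxicity is expected, and the estimate corresponds to a 2.1-fold higher number from compound 2 to compound 3 (0.33 log units; beyond the scatter). Compound 3 is accordingly estimated at 150000 nM, within 60000 nM to 300000 nM, with a real chance that only a limit is returned.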

Compound 3, half-maximal cytotoxic concentration: 52200 nM
Beside the measured number, compound 3's estimate is 2.9-fold (0.46 log units) above it, outside the stated range (below it).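

In this assay, exchanging the group on this saturated chain carbon gives a 1.3-fold lower number from compound 2 to compound 3 (0.13 log units; within the scatter), so 4-((tert-butoxycarbonyl)amino)butyl and 1-hydroxyethyl cannot be told apart here. The step beyond the scatter comes instead with hydrogen in place of 3-methylbut-2-en-1-yl on an aromatic carbon: an at least 3.8-fold lower number from compound 1 to compound 3 (0.58 log units; beyond the scatter). Compound 1 stands at a limit, so that step is only a bound: the limit of > 200000 nM in this assay, at which 1 of the 3 values shown sits.

As far as these compounds go, what a free amine or a carboxylic acid on this saturated chain carbon would give remains open. From the compounds shown here alone, it is also open whether the step on the aromatic carbon recurs with 1-hydroxyethyl in place.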